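The compounds below may be only part of what the source reports. "The series", "measured", "known", "first", "only" and "open" are said of these compounds alone.

Compound 1 `CCCNC(=C\C(=O)/C=C/c1ccc(O)c(OC)c1)/C=C/c1ccc(O)c(OC)c1` was tested in a functional assay on HT-29 cells (Homo sapiens) for inhibition, read by sulforhodamine B assay, with a stated time of 72 h (on this read-out higher numbers stand for weaker inhibition and lower numbers for stronger inhibition), and gives > 25000 nM, which is a limit of the assay rather than a number. Compound 2 `CCC(C)NC(=C\C(=O)/C=C/c1ccc(OC(C)=O)c(OC)c1)/C=C/c1ccc(OC(C)=O)c(OC)c1` likewise gives > 25000 nM in this assay, again a limit. Both measured values therefore sit at the limit of > 25000 nM in this assay, at which 2 of the 2 values shown sit, so compound 1 stands level with everything measured so far. Compound 3 `CCC(C)NC(=C\C(=O)/C=C/c1ccc(O)c(OC)c1)/C=C/c1ccc(O)c(OC)c1` has not been measured in this assay; it differs from compound 1 by methyl in place of hydrogen on a saturated chain carbon bound to an amine nitrogen and a saturated chain carbon. Since compound 1 sits at the limit of > 25000 nM in this assay, at which 2 of the 2 values shown sit, the step that the limit leaves unreadable from compound 1 to compound 3 is expected to be none beyond the scatter. Compound 3 is thus expected to give 30000 nM in this assay, between 10000 nM and 100000 nM.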

Compound 3, half-maximal inhibitory concentration: 22300 nM
Compound 3: middle estimate off by 1.3-fold (0.13 log units), on the high side; the range from low to high includes it.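

For the compounds shown here, compound 3 gives the first actual number in this assay, so methyl in place of hydrogen at this saturated chain carbon can now be read against a measured value, not only against limits. The step is an at least 1.1-fold lower number from compound 1 to compound 3 (0.04 log units; that floor lies within the scatter), which is only a floor, and it shows no change beyond the scatter. The true size of the step stays unfixed, since compound 1 gives only a limit: the limit of > 25000 nM in this assay, at which 2 of the 3 values shown sit.

Open, from the compounds shown here alone, is how a longer chain or a tert-butyl group in place of sec-butyl would read in this assay. Also open, going by these compounds, is whether a hydroxyl or an amine on that chain would move the value.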